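A few compounds are considered here, and "the series" means these few. Any claim that something is new, unique, unknown or untested is made for them only; others in the source may bear on it.

Compound 1 `Nc1nn2c(O)cc(-c3ccccc3)nc2c1[N+](=O)[O-]` sits at a limit of an ADME assay (Homo sapiens) for cytotoxicity (on this read-out higher numbers stand for lower toxicity in this test and lower numbers for higher toxicity in this test), in this study; in this assay compound 1 gives > 100 ug/mL, which is a limit and not a number. Compound 2 `Nc1nn2c(O)cc(-c3ccccc3F)nc2c1[N+](=O)[O-]` in this assay gives 66.5 ug/mL. Compound 3 `NNCc1cc(O)n2nc(N)c([N+](=O)[O-])c2n1` in this assay gives 42.6 ug/mL.

Compound 2 holds the highest of the two numbers; its nearest neighbour is compound 3, with a 1.6-fold lower number from compound 2 to compound 3 (0.19 log units; within the scatter). Compound 4 `CCSC(N)NCc1cc(O)n2nc(N)c([N+](=O)[O-])c2n1` is not yet measured. The change from compound 2 is ((amino(ethylsulfanyl)methyl)amino)methyl in place of 2-fluorophenyl on an aromatic carbon.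

Among the measured compounds shown here, two measured steps bear on this, both exchanging an aryl group for a chain at the same aromatic carbon: a 1.6-fold lower number from compound 2 to compound 3 (0.19 log units; within the scatter) and an at least 2.3-fold lower number from compound 1 to compound 3 (0.37 log units; beyond the scatter). The first lies within the scatter, the second is at least modest. Compound 4 is therefore expected to show a small lowering, a 1.5-fold lower number from compound 2 to compound 4 (0.17 log units; within the scatter), possibly none beyond the scatter. Compound 4 is estimated at 45 ug/mL, between 22 ug/mL and 95 ug/mL.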

Compound 4, half-maximal cytotoxic concentration: > 50 ug/mL
Compound 4 gave a limit, no number; the forecaster's own chance of this, stated with the estimate: 10%; middle value at least 1.1-fold (0.04 log units) from the limit.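

In this assay compound 4 gives > 50 ug/mL, which is a limit and not a number. Amino(ethylsulfanyl)methyl in place of amino on the amine nitrogen gives an at least 1.1-fold higher number from compound 3 to compound 4 (0.06 log units; that floor lies within the scatter), so the larger chain at this aromatic carbon brings no lowering, though that floor shows no gain beyond the scatter either. The steps to compound 4 from compound 1 and compound 2 cannot be read.

As far as these compounds go, how far the true number for compound 4 lies past its limit remains open, and with it whether replacing the aryl group with this chain lowers the number at all. Also open, from the compounds shown here alone, is whether methylsulfanyl in place of ethylsulfanyl, or a carboxylic acid at the chain end, would behave the same way.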